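Shortening the ether chain on a flavanone core

The compounds below may be only part of what the source reports. "The series", "measured", "known", "first", "only" and "open" are said of these compounds alone.

Of the compounds shown here, three that share one core have been measured in a functional assay on J774.A1 cells (Mus musculus) for inhibition, read by immunoassay, with a stated time of 12 h, tested at 30 uM; on this read-out lower numbers stand for less inhibition and higher numbers for more inhibition at the one concentration tested (going by the name of the read-out). Compound 1, `CCCOc1ccccc1C1CC(=O)c2ccccc2O1`, gives 43.6%. Compound 2, `CC(C)COc1ccccc1C1CC(=O)c2ccccc2O1`, gives 33.5%. Compound 3, `CC(C)=CCOc1ccccc1C1CC(=O)c2ccccc2O1`, gives 40.3%, which places it second highest of the three, its nearest neighbour being compound 1 and its furthest compound 2, both within the scatter.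

Compound 4, `CCOc1ccccc1C1CC(=O)c2ccccc2O1`, has not yet been measured. It differs from compound 3 in one place: methyl in place of 2-methylprop-1-en-1-yl on a saturated chain carbon bound to an oxygen on an aromatic ring.

Going by the values given here, two measured steps bear on this change. The step of a number 3.3 percentage points lower from compound 1 to compound 3 (within the scatter) replaced ethyl with 2-methylprop-1-en-1-yl at the same place; compound 4 reverses the direction of that kind of change and goes one carbon shorter still. The step of a number 6.8 percentage points higher from compound 2 to compound 3 (within the scatter) was likewise within the scatter. Among the compounds with values here, only the step of a number 10.1 percentage points lower from compound 1 to compound 2 (beyond the scatter) went beyond the scatter, and it concerns a different place. A step of a number 1.7 percentage points higher from compound 3 to compound 4 (within the scatter) is therefore expected, small and not beyond the scatter. Compound 4 is estimated to give 42%, between 30% and 54%.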

Compound 4, a percentage reported as inhibition, at one concentration (the size of the read-out at that concentration, not a potency): 27.7%
Beside the measured number, compound 4's estimate is 14.3 percentage points above it; the whole stated range lies above it.
By their numbers in this assay, from the lowest: compounds 4, 2, 3 and 1 (each within the scatter of the next, the first and the last beyond it).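

Going by these compounds alone, the ether chain at this place matters more than the earlier compounds suggested, since both earlier changes that swapped the whole end of the chain here stayed within the scatter. In this assay, within the data shown here, cutting the 3-methylbut-2-en-1-yl chain down to ethyl gives a step beyond the scatter (a number 12.6 percentage points lower from compound 3 to compound 4 (beyond the scatter)), and so does taking one methyl off the end of the chain of compound 1 (a number 15.9 percentage points lower from compound 1 to compound 4 (beyond the scatter)), yet methyl in place of isopropyl gives no step that can be told from scatter (a number 5.8 percentage points lower from compound 2 to compound 4 (within the scatter)). Nothing available explains why these changes differ in size.

The compounds shown leave open how a longer chain such as butyl, or an amine at the end of the chain, would read at this place. With one concentration per compound, these numbers also leave potency open.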